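A new benzyl group for compound 2

The source may report more compounds than this note shows. Statements on the series, on what has been measured and on what is new or still open speak of the compounds shown alone.

- compound 1 `Cc1ccc(CNC(=O)C(=O)N[C@@H](C)C(=O)N[C@@H](CC(=O)O)C(=O)COc2c(F)c(F)cc(F)c2F)cc1` gives 50 nM as its value
- compound 2 `C[C@H](NC(=O)C(=O)NCc1ccc(F)cc1)C(=O)N[C@@H](CC(=O)O)C(=O)COc1c(F)c(F)cc(F)c1F` gives 197 nM as its value

These two numbers come from a functional assay on Jurkat cells (Homo sapiens) (a lower number here means a stronger inhibitor, a higher number a weaker inhibitor), and are the only ones measured so far. Compound 2 has the higher number of the pair (197 nM), which makes it the weaker inhibitor of the two.

Compound 3 `C[C@H](NC(=O)C(=O)NCc1c(Cl)cccc1Cl)C(=O)N[C@@H](CC(=O)O)C(=O)COc1c(F)c(F)cc(F)c1F` keeps the rest of compound 2 and changes one group: 2,6-dichlorophenyl in place of 4-fluorophenyl on a saturated chain carbon bound to an amide-type nitrogen.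

Among the compounds with values here, no measured step makes this exact swap. The closest evidence is the change of methyl to fluoro on an aromatic carbon (a 3.9-fold higher number from compound 1 to compound 2 (0.60 log units; beyond the scatter)), a modest step. Within the data shown here, with only that step to go on, a similarly modest step is expected in this assay rather than a large one. The data do not settle its direction, so the lean toward a lower number is only a judgement. The estimated step is modest (a 2.2-fold lower number from compound 2 to compound 3 (0.34 log units; beyond the scatter)). For compound 3 the expected value is 90 nM (estimated range 22 nM to 360 nM).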

Compound 3, half-maximal inhibitory concentration: 110 nM
For compound 3 the middle estimate is 1.2-fold (0.09 log units) below the measured one, and the stated range covers the measured number.
By their numbers in this assay, from the lowest: compound 1; then compounds 3 and 2 (each within the scatter of the next).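

In this assay, exchanging the 4-fluorobenzyl group for the 2,6-dichlorobenzyl group gives a 1.8-fold lower number from compound 2 to compound 3 (0.25 log units; within the scatter) and so cannot be told apart from repeat-measurement noise. This shows that the amide-bound benzyl position tolerates a larger change than the earlier pair showed: two chlorine atoms can replace the single fluorine without a clear change in the number. The 4-methylbenzyl group of compound 1 still gives the strongest inhibitor of the three, with a 2.2-fold higher number from compound 1 to compound 3 (0.34 log units; beyond the scatter) as the step to the dichloro compound, but nothing here offers an independent measurement that explains any of these differences.

From the compounds shown here alone, it remains open how an unsubstituted benzyl group, which carries neither methyl nor halogen, would compare, and that compound would give the series a common baseline. A 2-chlorobenzyl or 4-chlorobenzyl group would help separate the effect of the halogen itself from that of its placement, while a 2-phenylethyl group, with its longer chain, would test how far the ring can move from the amide nitrogen.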